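The source may report more compounds than this note shows. Statements on the series, on what has been measured and on what is new or still open speak of the compounds shown alone.

Compounds measured so far:
compound 1 `C=CCOc1cc(OC)c(C(=O)/C=C/c2ccc(C)cc2)c(OCC=C)c1` gives 211000 nM;
compound 2 `C=CCOc1cc(OC)c(C(=O)/C=C/c2ccc([N+](=O)[O-])cc2)c(OCC=C)c1` gives 12600 nM;
compound 3 `C=CCOc1cc(OC)c(C(=O)/C=C/c2cc(OC)c(OC)c(OC)c2)c(OCC=C)c1` gives 40900 nM.

All three share one core and differ only in the aryl group at the end of the enone chain. In an ADME assay on Vero cells (Chlorocebus sabaeus) for cytotoxicity, read by MTT assay (a higher number here means a weaker inhibitor, a lower number a stronger inhibitor), compound 2 gives the lowest of the three numbers: compound 3 sits above it and compound 1 further still. Within the data shown here, the one step that can be traced to a single change is a 17-fold lower number from compound 1 to compound 2 (1.22 log units; beyond the scatter), a large move toward a stronger inhibitor.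

Compound 4 `C=CCOc1cc(OC)c(C(=O)/C=C/c2ccncc2)c(OCC=C)c1` has not yet been measured in this assay. It differs from compound 2 in one place: pyridin-4-yl in place of 4-nitrophenyl on a double-bonded chain carbon bound to a double-bonded chain carbon. Among the measured compounds shown here, no measured pair shows this exchange, so the expectation rests on what the three values show. Compound 2, which carries the nitro group, stands lowest, and the step from compound 1 to compound 2 shows how much that single group moved the number. Taking the nitro group away with the rest of its ring is expected to move compound 4 back toward the higher numbers of compound 1 and compound 3, which means an expected step of a 4.8-fold higher number from compound 2 to compound 4 (0.68 log units; beyond the scatter). The estimate for compound 4 is therefore 60000 nM, within 20000 nM to 200000 nM.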

Compound 4, half-maximal inhibitory concentration: 2800 nM
Estimate against measurement, compound 4: 21-fold (1.33 log units) above, and the stated range ends above it.
By their numbers in this assay, from the lowest: compound 4; then compound 2; then compound 3; then compound 1.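

In this assay, pyridin-4-yl in place of 4-nitrophenyl gives a 4.5-fold lower number from compound 2 to compound 4 (0.65 log units; beyond the scatter), so at this place on the double-bonded chain carbon the lowest number of the four does not depend on the nitro group, and a ring with a single hetero atom and fewer heavy atoms goes further than the nitro-bearing ring. Set against 4-methylphenyl, the same ring gives a 75-fold lower number from compound 1 to compound 4 (1.88 log units; beyond the scatter), a larger move than the one seen with the nitro group, which shows that this end of the enone chain can shift the number across a wider span than the first three compounds revealed. Nothing available here explains why pyridin-4-yl goes with the lower number.

The compounds shown leave open whether the ring nitrogen must stand where it does in pyridin-4-yl, since pyridin-3-yl and pyridin-2-yl do not appear among them. They also leave open how a phenyl ring carrying an amine or a carboxylic acid would compare at this place, and whether the order of the four would hold if the allyl ether chains on the shared core were replaced by longer chains.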